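The source may report more compounds than this note shows. Statements on the series, on what has been measured and on what is new or still open speak of the compounds shown alone.

Compound 1, `CS/C(=N\C(=O)c1ccno1)NC(=O)c1ccno1`: in a functional assay on PC-3 cells (Homo sapiens) for cytotoxicity, read by MTT assay, with a stated time of 72 h (a lower number here means that less compound is tolerated, a higher number that more compound is tolerated), compound 1 gives > 100000 nM, which is a limit of the assay rather than a number.
Compound 2, `CS/C(=N\C(=O)c1csc([N+](=O)[O-])c1)NC(=O)c1csc([N+](=O)[O-])c1`: in this assay compound 2 gives > 100000 nM, again a limit of the assay.
Compound 3, `O=C(/N=C(/NC(=O)c1ccco1)[Se]Cc1ccccc1)c1ccco1`: in this assay compound 3 gives 84800 nM.

Compound 2 therefore stands only at a limit in this assay, and one further value shown is a limit as well, namely (the limit of > 100000 nM in this assay, at which 2 of the 3 values shown sit). Among the compounds with values here, no pair of measured compounds differs in a single place, so nothing measured tells how one change alone moves the read-out.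

Compound 4, `C[Se]/C(=N\C(=O)c1csc([N+](=O)[O-])c1)NC(=O)c1csc([N+](=O)[O-])c1`, has not yet been measured in this assay. It differs from compound 2 in one place: a group of 2 heavy atoms (1 carbon, 1 selenium; no ring) in place of a group of 2 heavy atoms (1 carbon, 1 sulfur; no ring), on a carbon with a double bond to nitrogen. Within the data shown here, the only measured compound carrying selenium, compound 3, gives a value near the limit, but it differs from compound 2 in other places too and cannot be read as a step.

For the change from compound 2 to compound 4 no step beyond the usual scatter of this assay is expected, in either direction, and a fair chance remains that the assay again reports only a limit. Compound 4 is expected to give about 100000 nM, between 30000 nM and 300000 nM. The expected step is a number no higher from compound 2 to compound 4 (the limit leaves the size open).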

Compound 4, concentration lethal to 50% of the cells: > 100000 nM
Compound 4: a limit, no number (the forecaster's own chance of this, stated with the estimate: 60%); the middle value sits exactly at the limit.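

Compound 2 and compound 4 both stand at a limit of this assay and not at a number, so no step can be read between them, because their shared result is only this: the limit of > 100000 nM in this assay, at which 3 of the 4 values shown sit.

The compounds shown leave open whether replacing methylsulfanyl with the selenium-carrying group alone moves the read-out at all, and if so, how far and in which direction.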